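Dropping a Chloro Group: Expected Cytotoxicity of Compound 3

This account rests on a few compounds, and the source may have more. Where it says the series, first, only, none or still open, it means among the compounds named here.

Two compounds have so far been examined in an ADME assay on MT2 cells (Homo sapiens) for cytotoxicity, read by MTT assay; on this read-out higher numbers stand for lower toxicity in this test and lower numbers for higher toxicity in this test. Compound 1, `Fc1cccc(F)c1Cc1cnc(Nc2ccc(Oc3cccnc3)c(Cl)c2)o1`, gives 16000 nM. Compound 2, `Fc1cccc(F)c1Cc1cnc(Nc2ccc(Oc3ccncc3)c(Cl)c2)o1`, gives 21000 nM. The only difference between them is pyridin-4-yl in place of pyridin-3-yl on an oxygen on an aromatic ring, and the step of a 1.3-fold higher number from compound 1 to compound 2 (0.12 log units; within the scatter) shows that this exchange does not move the read-out beyond the scatter. Within the data shown here, compound 2 therefore stands alongside compound 1, its only measured neighbour, with no separation that can be called real.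

Compound 3, `Fc1cccc(F)c1Cc1cnc(Nc2ccc(Oc3ccncc3)cc2)o1`, is the next compound to be tested in this assay. It differs from compound 2 by hydrogen in place of chloro on an aromatic carbon. Among the measured compounds shown here, no measured step touches this change: the single step available concerns the pyridinyl group and not the chloro, so nothing in the data argues for a shift in either direction. Compound 3 is therefore expected to give about 21000 nM, within a range from 9000 nM to 50000 nM. The estimated step of no change at the digits printed from compound 2 to compound 3 (within the scatter) is expected to stay within the scatter.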

Compound 3, half-maximal cytotoxic concentration: 21000 nM
The estimate for compound 3 equals the measured number at the digits printed, within the range that was stated.
By their numbers in this assay, from the lowest: compounds 1, 2 and 3 (each within the scatter of the next).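

In this assay, replacing chloro with hydrogen on the aromatic carbon ortho to a (pyridin-4-yl)oxy group gives no change at the digits printed from compound 2 to compound 3 (within the scatter). Among these compounds, the earlier pair varied only the pyridinyl group, so this is the first reading at this position, and it shows that compounds with chloro or hydrogen there cannot be told apart in this test when the pyridin-4-yl group is present. No supporting measurement is available to explain this result.

With only chloro and hydrogen shown at this position, it remains open whether a larger or different group, such as methoxy, trifluoromethyl or an amine, would give a number beyond the scatter. From the compounds shown here alone, it is also open whether hydrogen in place of chloro would read the same alongside the pyridin-3-yl group of compound 1, and the rest of the shared core, which is the same in all three compounds, remains untested by these results.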